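Swapping the Sugar on a Triazole-Linked Core

A few compounds are considered here, and "the series" means these few. Any claim that something is new, unique, unknown or untested is made for them only; others in the source may bear on it.

Two compounds built on a shared core have been examined in a toxicity assay on HEK-293T cells (Homo sapiens) for cytotoxicity, read by MTT assay, with a stated time of 72 h; on this read-out lower numbers stand for stronger inhibition and higher numbers for weaker inhibition. Compound 1 `CN1CCN(CCCCCCn2c3c(c4ccccc42)C(=O)c2c[n+]([O-])c4ccccc4c2C3=O)CC1` gives 5800 nM in this assay, and compound 2 `O=C1c2c[n+]([O-])c3ccccc3c2C(=O)c2c1c1ccccc1n2Cc1cn([C@H]2C[C@H](O)[C@@H](CO)O2)nn1` gives 3600 nM. Compound 2 has the lowest of these two numbers, but compound 1 sits only slightly higher, and that gap lies within the scatter, so no order between them can be claimed. Within the data shown here, no step between measured compounds that differ in one place has been recorded. Compound 3 `CC1(C)OCC(Cn2cc(Cn3c4c(c5ccccc53)C(=O)c3c[n+]([O-])c5ccccc5c3C4=O)nn2)O1` has not yet been measured. It differs from compound 2 in one place: (2,2-dimethyl-1,3-dioxolan-4-yl)methyl in place of 4-hydroxy-5-(hydroxymethyl)oxolan-2-yl on an aromatic nitrogen. Among the measured compounds shown here, with no measured step of this kind available, the change from compound 2 to compound 3 is expected to be small, with no clear direction beyond the scatter, and the estimate rests on compound 2 alone, at 3600 nM. The expected step is a 1.2-fold lower number from compound 2 to compound 3 (0.08 log units; within the scatter). Compound 3 is therefore estimated at 3000 nM in this assay, with a range from 1000 nM to 9000 nM.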

Compound 3, half-maximal inhibitory concentration: 5510 nM
Estimate against measurement, compound 3: 1.8-fold (0.26 log units) below, and the stated range covers the measured number.
By their numbers in this assay, from the lowest: compounds 2, 3 and 1 (each within the scatter of the next).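

In this assay, among these compounds, the exchange of 4-hydroxy-5-(hydroxymethyl)oxolan-2-yl for (2,2-dimethyl-1,3-dioxolan-4-yl)methyl on this aromatic nitrogen gives a 1.5-fold higher number from compound 2 to compound 3 (0.18 log units; within the scatter) as the only measured step at this position. It shows that going from a group with 2 hydrogen-bond donors and 3 defined stereocentres to one with 0 hydrogen-bond donors, at the same count of 8 heavy atoms, keeps the two numbers within the scatter of each other. No measurement on these compounds accounts for this result.

Going by these compounds, whether a carboxylic acid or a primary amine carried on this aromatic nitrogen would give a step beyond the scatter remains open. So does the outcome for a group larger than these two, such as a longer chain ending in a phenyl ring.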